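This account rests on a few compounds, and the source may have more. Where it says the series, first, only, none or still open, it means among the compounds named here.

Compound 1 (`CCOC(=O)Cn1cc(CNC(=O)c2cn(Cc3ccccc3)nn2)nn1`) gives 35000 nM in a functional assay on B16 cells (Mus musculus) for cytotoxicity, read by MTT assay, with a stated time of 48 h (on this read-out lower numbers stand for stronger inhibition and higher numbers for weaker inhibition), and compound 2 (`O=C(Cn1cc(C(=O)NCc2cn(Cc3ccccc3)nn2)nn1)OCc1ccccc1`) gives 22400 nM there, the two numbers lying within the scatter of each other. Compound 3 (`CCOC(=O)Cn1cc(CNC(=O)c2cn(CC(=O)OCc3ccccc3)nn2)nn1`) differs from compound 2 by ethoxycarbonyl in place of phenyl on a saturated chain carbon bound to an aromatic nitrogen with ethoxycarbonyl in place of phenyl on a saturated chain carbon bound to an aromatic nitrogen. Among the compounds with values here, no measured step speaks to this change, so in this assay no shift beyond the scatter is expected in either direction. The expected change a 1.3-fold higher number from compound 2 to compound 3 (0.13 log units; within the scatter) stays within the scatter. For compound 3 the estimated value is 30000 nM with 12000 nM and 70000 nM as its expected ends.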

Compound 3, half-maximal inhibitory concentration: > 100000 nM
Compound 3 gave a limit, no number; the forecaster's own chance of this, stated with the estimate: 10%; at least 3.3-fold (0.52 log units) between middle value and limit.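

In this assay, replacing the phenyl on a saturated chain carbon bound to an aromatic nitrogen costs inhibition: ethoxycarbonyl in its place gives an at least 4.4-fold higher number from compound 2 to compound 3 (0.64 log units; beyond the scatter), and benzyloxycarbonyl in its place gives an at least 2.8-fold higher number from compound 1 to compound 3 (0.45 log units; beyond the scatter). Compound 1 and compound 2, which lie within the scatter of each other, had shown no step at this position. Compound 3 carries a limit and not a number, so both steps have no upper size: the limit of > 100000 nM in this assay, at which 1 of the 3 values shown sits.

The compounds shown leave open whether a pyridine ring or a carboxylic acid at this place would restore the inhibition seen with phenyl.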